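Anilide series: aryl in place of alkyl on the amino nitrogen

This account rests on a few compounds, and the source may have more. Where it says the series, first, only, none or still open, it means among the compounds named here.

Measured so far in an in vitro assay on HEK-tsA201 cells for antagonist activity at Neuronal acetylcholine receptor; alpha4/beta2 (Homo sapiens), read by fluorescence and calcium flux; on this read-out higher numbers stand for weaker inhibition and lower numbers for stronger inhibition:
compound 1 `C=CCOc1ccc(C(=O)Nc2cccc(Cl)n2)cc1`: > 100000 nM (a limit of the assay, not a number)
compound 2 `CCCOc1ccc(C(=O)Nc2cnccn2)cc1`: 23200 nM
compound 3 `CCCNc1cccc(NC(=O)c2ccc(OCCC)cc2)n1`: 15400 nM

Compound 1 reaches only the limit of this assay; as the evidence notes, (the limit of > 100000 nM in this assay, at which 1 of the 3 values shown sits), so it gives no number to compare. Of the two numbers, compound 3 has the lower one, but its nearest neighbour compound 2 sits within the usual scatter, so no order between the two is claimed.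

The next compound, compound 4 `CCCOc1ccc(C(=O)Nc2cccc(Nc3ccc(OC)cc3)n2)cc1`, differs from compound 3 by 4-methoxyphenyl in place of propyl on a nitrogen on an aromatic ring. For the measured compounds named here, no pair among the measured compounds shows this kind of change, so there is no measured step to lean on. The expectation is a small step in this assay, if any beyond the scatter, in either direction; the step from compound 3 to compound 4 is expected to be a 1.3-fold lower number from compound 3 to compound 4 (0.11 log units; within the scatter). Compound 4 is therefore estimated at 12000 nM, with a range from 3000 nM to 50000 nM.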

Compound 4, half-maximal inhibitory concentration: > 100000 nM
Compound 4: only a limit was reported; the forecaster's own chance of this, stated with the estimate: 15%; middle value at least 8.3-fold (0.92 log units) from the limit.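

For the compounds shown here, on the nitrogen on an aromatic ring, propylamino to (4-methoxyphenyl)amino is the first single change that can be read in this assay, and it gives an at least 6.4-fold higher number from compound 3 to compound 4 (0.81 log units; beyond the scatter). Going by these compounds alone, this places a clear loss of inhibition at a position for which the earlier compounds offered no measured step, and the aryl group is not tolerated here as the propyl group is. Compound 4 at > 100000 nM is a limit of the assay and not a number, so it stands with compound 1 at that limit: the limit of > 100000 nM in this assay, at which 2 of the 4 values shown sit.

The compounds shown do not separate the effect of the aromatic ring from that of its methoxy group, and an unsubstituted phenyl on the same nitrogen would address this. As far as these compounds go, how a longer chain such as butyl or a small ring such as cyclopropyl would read at this nitrogen also stays open.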